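The source may hold more compounds than are shown below. What is called first, only, known or untested is meant among the compounds shown, and "the series" means these compounds.

Series notes. Compound 1 `CCOC(=O)c1c(-c2ccc(F)cc2)oc2ccc(OCCN3C(=O)C(=O)c4ccccc43)cc12` and compound 2 `CCOC(=O)c1c(-c2ccc(F)cc2)oc2ccc(OCCN3C(=O)C(=O)c4cc(OC)ccc43)cc12` share one core and differ only in the change (methoxy in place of hydrogen on an aromatic carbon). In an ADME assay on CHO cells (Cricetulus griseus) for cytotoxicity, read by MTT assay, with a stated time of 72 h (a higher number here means that more compound is tolerated, a lower number that less compound is tolerated), compound 1 gives 128000 nM, and compound 2 gives 512000 nM; the step of a 4.0-fold higher number from compound 1 to compound 2 (0.60 log units; beyond the scatter) is modest but beyond the scatter. Compound 3 `CCOC(=O)c1c(-c2ccccc2)oc2ccc(OCCCN3C(=O)/C(=N/O)c4ccccc43)cc12` has a different core, and the difference between the two cores is not broken down here. In this assay compound 3 gives 512000 nM, level with compound 2 at the digits shown and well apart from compound 1.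

Compound 4 `CCOC(=O)c1c(-c2ccccc2)oc2ccc(OCCCN3C(=O)/C(=N/O)c4cc(OC)ccc43)cc12` carries the same change on the core of compound 3, namely (methoxy in place of hydrogen on an aromatic carbon); the place of the entering group is described in the same words for both pairs, so this is the same change made twice. From the earlier step of a 4.0-fold higher number from compound 1 to compound 2 (0.60 log units; beyond the scatter) a rise in the same direction is expected for compound 4 in this assay, but a smaller one, since compound 3 already stands at the top of the measured range and a reading there may turn into a limit. The step expected from compound 3 to compound 4 is a 2.0-fold higher number from compound 3 to compound 4 (0.29 log units; within the scatter), giving for compound 4 an estimate of 1000000 nM, between 400000 nM and 2500000 nM.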

Compound 4, half-maximal cytotoxic concentration: 512000 nM
Beside the measured number, compound 4's estimate is 2.0-fold (0.29 log units) above it, within the range that was stated.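

In this assay, methoxy in place of hydrogen on an aromatic carbon gives no change at the digits printed from compound 3 to compound 4 (within the scatter), and this step does not match the one seen on the other core: the same change on two cores in this assay, a 4.0-fold higher number (0.60 log units; beyond the scatter) from compound 1 to compound 2 and no change at the digits printed (within the scatter) from compound 3 to compound 4, 4.0-fold (0.60 log units) apart, beyond the scatter of two such steps. Within this series, then, the size of the step on one core does not predict its size on the other, and the change cannot be treated as a fixed increment across these two cores. Among the compounds shown here, only two pairs support this reading, and the difference between the cores is not broken down, so the data do not show which feature of the cores accounts for the gap or how the change would behave on any further core.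

Open questions are whether a chloro group, a hydroxyl group or a dimethylamino group entering at the same aromatic carbon would follow either of the two steps. From the compounds shown here alone, it also remains open whether the gap between the two steps persists on cores with a longer chain or with a carboxylic acid on the ester position.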